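Series notes: furan to carboxyphenoxy on compound 1

The compounds below may be only part of what the source reports. "The series", "measured", "known", "first", "only" and "open" are said of these compounds alone.

Compound 1 `Cc1ccccc1-n1nc(C)c2c1NC(=O)[C@H](C)S[C@@H]2c1ccc(-c2ccoc2)cc1` gives 3500 nM in an assay on isolated protein for agonist activity at Bile acid receptor (Homo sapiens), read by AlphaScreen, with a stated time of 30 min (a higher number here means that more compound is needed for the effect, a lower number that less compound is needed), the highest of the three numbers. Compound 3 `Cc1ccc(-n2nc(C)c3c2NC(=O)[C@H](C)S[C@@H]3c2ccc(Oc3ccccc3)cc2)cc1` gives 3400 nM, within the scatter of compound 1, while compound 2 `CCCc1ccccc1-n1nc(C)c2c1NC(=O)[C@H](C)S[C@@H]2c1ccc(Oc2ccccc2)cc1` gives 1100 nM, beyond it. Among the compounds with values here, the one measured step, a 3.1-fold higher number from compound 2 to compound 3 (0.49 log units; beyond the scatter), changes the group on the aromatic nitrogen and does not bear on the change now considered. Compound 4 `Cc1ccccc1-n1nc(C)c2c1NC(=O)[C@H](C)S[C@@H]2c1ccc(Oc2cccc(C(=O)O)c2)cc1` differs from compound 1 by 3-carboxyphenoxy in place of furan-3-yl on an aromatic carbon. Within the data shown here, no measured pair isolates this change, so no step can be read across; the expectation rests on the spread of the three values alone. For compound 4 the step of a 2.3-fold lower number from compound 1 to compound 4 (0.37 log units; beyond the scatter) is expected, a modest move to a lower number. Compound 4 is estimated at 1500 nM, with a range of 400 nM to 5000 nM.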

Compound 4, half-maximal effective concentration: "not active" (no number reported)
For compound 4 the study gives words and no number, and the estimate cannot be compared.
By their numbers in this assay, from the lowest: compound 2; then compounds 3 and 1 (each within the scatter of the next).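

Within the data shown here, compound 4 is reported only in words, so no step from compound 1 to compound 4 can be read, and no evidence bears on this result. The compounds shown leave open how 3-carboxyphenoxy compares numerically with furan-3-yl.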